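Chloro in place of iodo on the series core

The source may hold more compounds than are shown below. What is called first, only, known or untested is meant among the compounds shown, and "the series" means these compounds.

Working notes on the step away from compound 1 (`Nc1nc(=O)n([C@@H]2CS[C@@H](CO)O2)cc1I`). In a functional assay on Vero cells (Chlorocebus sabaeus) for inhibition (a higher number here means a weaker inhibitor, a lower number a stronger inhibitor), compound 1 gives > 100000 nM, which is a limit of the assay and not a number. That places it here: the limit of > 100000 nM in this assay, at which 1 of the 2 values shown sits. For the measured compounds named here, the only true number so far belongs to compound 2 (`Nc1nc(F)nc2c1ncn2[C@@H]1CS[C@@H](CO)O1`), which gives 45400 nM in this assay on a different core.

Compound 3 (`Nc1nc(=O)n([C@@H]2CS[C@@H](CO)O2)cc1Cl`) keeps the core of compound 1 and carries chloro in place of iodo on an aromatic carbon, ortho to an amino group: chloro in place of iodo on an aromatic carbon. Going by the values given here, no measured pair gauges this exchange, and the starting point is only a limit, so any direction rests on little. The expectation is therefore no step beyond the scatter in this assay, with compound 3 staying weak. The estimated step is an at least 1.1-fold lower number from compound 1 to compound 3 (0.04 log units; that floor lies within the scatter). A report of only a limit is also expected to be the likeliest outcome for compound 3.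

The estimated value for compound 3 is 90000 nM, with an expected range of 40000 nM to 150000 nM.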

Compound 3, half-maximal inhibitory concentration: 31200 nM
Estimate against measurement, compound 3: 2.9-fold (0.46 log units) above, and the stated range ends above it.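

In this assay, chloro in place of iodo on the aromatic carbon ortho to an amino group gives an at least 3.2-fold lower number from compound 1 to compound 3 (0.50 log units; beyond the scatter), so activity at this position responds to which halogen it carries. For the compounds shown here, compound 3 gives 31200 nM, the first true number on the core of compound 1, and this gives later changes on that core a measured reference point. The full size of the step cannot be stated because the starting compound gives only a limit, so the step is a floor and the real difference may be larger: the limit of > 100000 nM in this assay, at which 1 of the 3 values shown sits.

The compounds shown compare only iodo and chloro at this carbon, so one pair cannot establish a trend across substituents, and whether a bromo, a methyl or a nitrile in the same place would lower the number further stays open. Also open, from the compounds shown here alone, is whether the same exchange would give a comparable step on a different core, or with a change elsewhere on the core of compound 1, such as at the amino group or the hydroxymethyl group.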